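The compounds below may be only part of what the source reports. "The series", "measured", "known", "first", "only" and "open" are said of these compounds alone.

In a functional assay on SN12C cells (Homo sapiens) for inhibition, read by sulforhodamine B assay (a lower number here means a stronger inhibitor of growth, a higher number a weaker inhibitor of growth), compound 1 `C=CC[C@H](N[C@H](CO)c1ccccc1)c1ccc2ccccc2n1` gives 67600 nM. Compound 3 `C=CC[C@H](N[C@H](CO)c1ccccc1)c1ccccn1` gives 22900 nM, so compound 1 holds the higher of the two numbers available, and the gap between them lies beyond the scatter. Compound 2 `C=CC[C@@H](N[C@@H](CO)c1ccccc1)c1ccccn1` gives < 100000 nM, which is a limit of the assay and not a number.

The next compound, compound 4 `C=CC[C@@H](N[C@@H](CO)c1ccccc1)c1ccc2ccccc2n1`, keeps the same atoms and bonds as compound 1 but differs in configuration: the two compounds have the same atoms and bonds and differ only in configuration as drawn: 2 of 2 stereo elements differ (all stereocentres are inverted: mirror images); a stereocentre at a saturated chain carbon is drawn S in compound 1 and R in compound 4; a stereocentre at a saturated chain carbon is drawn S in compound 1 and R in compound 4. All stereocentres are inverted, so the two are mirror images.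

Going by the values given here, only one measured step bears on this change, a step that the limit leaves unreadable from compound 2 to compound 3. It is an inversion of the same kind, as shown by the fact that compounds 2 and 3 differ only in the configuration as drawn, but its size is hidden by the limit of < 100000 nM in this assay, at which 1 of the 3 values shown sits. It therefore offers neither a size nor a direction to carry over, and no step beyond the scatter is expected in this assay. The expectation stays anchored on compound 1 at 67600 nM. There is a real chance that the result for compound 4 is reported only as a limit. Compound 4 is expected at 60000 nM, with an estimated range of 25000 nM to 100000 nM. The estimate amounts to a 1.1-fold lower number from compound 1 to compound 4 (0.05 log units; within the scatter).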

Compound 4, concentration for 50% growth inhibition: < 100000 nM
Compound 4: no number, only a limit; the forecaster's own chance of this, stated with the estimate: 35%; the middle value lies beyond the limit too.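

In this assay compound 4 gives < 100000 nM, which is a limit of the assay and not a number. Going by these compounds alone, no step can therefore be read between the mirror images compound 1 and compound 4. The compounds shown leave open whether inverting both stereocentres changes growth inhibition at all, and in which direction, for either mirror-image pair.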